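This account rests on a few compounds, and the source may have more. Where it says the series, first, only, none or still open, it means among the compounds named here.

Compound 3 `COc1ccc(-c2cc(=O)c3c(OC)cc(OC)cc3n2S(=O)(=O)c2cc(Cl)cc(Cl)c2O)cc1` is one of three compounds tested in a functional assay on SUP-B15 cells (Homo sapiens) for antiproliferative activity, with a stated time of 72 h (a lower number here means that less compound is needed, a higher number that more compound is needed for the effect), and each of them returned only a limit rather than a number. For compound 3 the result is > 37900 nM, a limit of the assay. Compound 1 `COc1ccc(-c2cc(=O)c3c(OC)cc(OC)cc3[nH]2)cc1` gave > 62000 nM, likewise a limit. Compound 2 `COc1ccc(-c2cc(=O)c3c(OC)cc(OC)cc3n2S(=O)(=O)c2ccc(F)cc2)cc1` gave > 65500 nM, again a limit. Consequently the step that the two limits leave unreadable from compound 1 to compound 2 and the step that the two limits leave unreadable from compound 2 to compound 3 cannot be sized. Compound 4 `COc1ccc(-c2cc(=O)c3c(OC)cc(OC)cc3n2S(=O)(=O)c2cccc(Br)c2)cc1` differs from compound 3 by 3-bromophenyl in place of 3,5-dichloro-2-hydroxyphenyl on a sulfonyl sulfur. For the measured compounds named here, no measured step bears on this change, and the three limits give no direction to expect. Compound 4 is therefore expected to give 60000 nM, within a range from 20000 nM to 200000 nM, most probably again as a limit. The expected step is a step that the limit leaves unreadable from compound 3 to compound 4.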

Compound 4, half-maximal effective concentration: > 58600 nM
Compound 4: only a limit was reported; the forecaster's own chance of this, stated with the estimate: 85%; the middle value does not contradict the limit.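

Compound 4 also returned only a limit, like compounds 1, 2 and 3, so none of its steps to those compounds can be read. From the compounds shown here alone, what stays open is whether any group on the sulfonyl sulfur gives a measurable value in this assay.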